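Trimethoxyphenyl on the enone arm of the shared core

The source may report more compounds than this note shows. Statements on the series, on what has been measured and on what is new or still open speak of the compounds shown alone.

Two members of the series have been run in an ADME assay on HEK293 cells (Homo sapiens) for antiproliferative activity, read by MTT assay, with a stated time of 24 h; on this read-out higher numbers stand for weaker inhibition and lower numbers for stronger inhibition. Compound 1 `COc1ccc(/C=C/C(=O)c2cc(-c3cc(OC)c(OC)c(OC)c3)n3nc(-c4ccccc4)cc3n2)cc1OC` gives 41000 nM in this assay. Compound 2 `COc1cc(-c2cc(C(=O)/C=C/c3ccc(C)cc3)nc3cc(-c4ccccc4)nn23)cc(OC)c1OC` carries a 4-methylphenyl on the double-bonded chain carbon in place of the 3,4-dimethoxyphenyl of compound 1. In this assay compound 2 gives 56100 nM. Among the compounds with values here, the only step with a number is a 1.4-fold higher number from compound 1 to compound 2 (0.14 log units; within the scatter), so on the two numbers so far compound 2 and compound 1 are not separated beyond the scatter.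

Compound 3 `COc1cc(/C=C/C(=O)c2cc(-c3cc(OC)c(OC)c(OC)c3)n3nc(-c4ccccc4)cc3n2)cc(OC)c1OC` is the next member to be measured. The change is 3,4,5-trimethoxyphenyl in place of 4-methylphenyl on a double-bonded chain carbon bound to a double-bonded chain carbon. Within the data shown here, the one measured step that bears on it is a 1.4-fold higher number from compound 1 to compound 2 (0.14 log units; within the scatter), which exchanged a methoxylated phenyl for the 4-methylphenyl at the same place and moved nothing beyond the scatter; compound 3 goes back from the 4-methylphenyl to a methoxylated phenyl, this time the 3,4,5-trimethoxyphenyl. No step beyond the scatter is therefore expected in this assay, and the expected step is a 1.2-fold lower number from compound 2 to compound 3 (0.10 log units; within the scatter). Compound 3 is estimated at 45000 nM in this assay, in a range from 18000 nM to 110000 nM.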

Compound 3, half-maximal inhibitory concentration: 41000 nM
The estimate for compound 3 lay 1.1-fold (0.04 log units) above the measured number; low and high end bracket the measured number.
By their numbers in this assay, from the lowest: compounds 1, 3 and 2 (each within the scatter of the next).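

In this assay, 3,4,5-trimethoxyphenyl in place of 4-methylphenyl on a double-bonded chain carbon bound to a double-bonded chain carbon gives a 1.4-fold lower number from compound 2 to compound 3 (0.14 log units; within the scatter) even though the entering group has 12 heavy atoms and 3 hydrogen-bond acceptors, against 7 heavy atoms and 0 hydrogen-bond acceptors for the group that leaves. Methoxy in place of hydrogen on an aromatic carbon then gives no change at the digits printed from compound 1 to compound 3 (within the scatter) and adds a second kind of change at this position, a single methoxy rather than an exchange of whole groups, which also leaves the read-out within the scatter, so all three aryl groups tried here remain unseparated in this assay. No independent measurement is available to explain this flat response.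

Going by these compounds, all three groups at this position are substituted phenyl rings, so it remains open whether a basic amine such as a dimethylamino group or a carboxylic acid on that ring would separate from them. On these data alone, it is also open whether replacing the ring with a longer alkyl chain would move the number beyond the scatter.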